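Replacing 3,5-difluorophenyl with cyclohexyl on the shared core

The source may hold more compounds than are shown below. What is called first, only, known or untested is meant among the compounds shown, and "the series" means these compounds.

Compound 1 `Cc1cccc(NC(=O)c2nn(C)c(-c3ccc(F)cc3)c2C)n1` and compound 2 `Cc1cccc(NC(=O)c2nn(C)c(-c3cc(F)cc(F)c3)c2C)n1` share one core and differ only in their fluorinated phenyl group. In an ADME assay on microsomes from liver (Mus musculus) for metabolic stability (a higher number here means that the compound lasts longer, a lower number that the compound disappears faster), compound 1 gives 0.6 h and compound 2 gives 0.3 h. These two values lie within the scatter of each other, so the measurements do not separate compound 2 from compound 1.

Compound 3 `Cc1cccc(NC(=O)c2nn(C)c(C3CCCCC3)c2C)n1` carries cyclohexyl in place of 3,5-difluorophenyl on an aromatic carbon. Within the data shown here, the only measured step, a 2.0-fold lower number from compound 1 to compound 2 (0.30 log units; within the scatter), exchanges one fluorinated phenyl group for another. Among the measured compounds shown here, it therefore gives little guidance on a non-aromatic ring, and no measured compound carries one. The estimate starts from compound 2 at 0.3 h and leans only slightly towards faster disappearance. The expected change is a 1.5-fold lower number from compound 2 to compound 3 (0.18 log units; within the scatter), and no step beyond the scatter is firmly expected. In this assay compound 3 is expected to show a half-life near 0.2 h, with an estimated range from 0.08 h to 0.5 h.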

Compound 3, half-life: 0.467 h
Compound 3: middle estimate off by 2.3-fold (0.37 log units), on the low side; the measured number falls inside the stated range.
By their numbers in this assay, from the lowest: compounds 2, 3 and 1 (each within the scatter of the next).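

In this assay, the exchange of 3,5-difluorophenyl for cyclohexyl gives a 1.6-fold higher number from compound 2 to compound 3 (0.19 log units; within the scatter) and the exchange of 4-fluorophenyl for cyclohexyl gives a 1.3-fold lower number from compound 1 to compound 3 (0.11 log units; within the scatter) on the same position, so neither step separates the compounds. The earlier compounds shown here carried only fluorinated phenyl groups on this aromatic carbon, whereas compound 3 shows that a non-aromatic ring of carbon only, without fluorine, can stand there with no step beyond the scatter in this assay. No evidence bearing on this result is available, so the data offer no explanation for it.

Going by these compounds, whether any group on this carbon can move the half-life beyond the scatter remains open, as all three compounds lie within the scatter of one another. A plain phenyl group would test the aromatic ring apart from its fluorine, while a piperidine ring with its amine nitrogen, a carboxylic acid or a longer chain such as n-butyl would show how far the result extends to groups unlike those in compound 1, compound 2 and compound 3.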